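This account rests on a few compounds, and the source may have more. Where it says the series, first, only, none or still open, it means among the compounds named here.

Measured so far:
- compound 1 `COc1cccc(/C=C2\CCC/C(=C\c3ccc(Cl)cc3Cl)C2=O)c1OC`: > 20000 nM, a limit of the assay
- compound 2 `COc1ccc(/C=C2\CCC/C(=C\c3ccc(Br)cc3)C2=O)cc1OC`: 4300 nM

For the measured compounds named here, in a functional assay on HT-1080 cells (Homo sapiens) for cytotoxicity, read by MTT assay, with a stated time of 72 h (on this read-out higher numbers stand for weaker inhibition and lower numbers for stronger inhibition), compound 2 gives 4300 nM, the only number in this set. Compound 1 sits at the limit of > 20000 nM in this assay, at which 1 of the 2 values shown sits. Compound 3 `COc1ccc(/C=C2\CCC/C(=C\c3ccc(O)c(O)c3)C2=O)cc1OC` differs from compound 2 in one place: 3,4-dihydroxyphenyl in place of 4-bromophenyl on a double-bonded chain carbon bound to a double-bonded ring carbon. Going by the values given here, no step between measured compounds is known, so the direction of this change is open; a step no larger than a modest loss, possibly none beyond the scatter, is expected in this assay, as a 1.9-fold higher number from compound 2 to compound 3 (0.27 log units; within the scatter). Compound 3 is estimated at 8000 nM, with a range from 2000 nM to 30000 nM.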

Compound 3, half-maximal inhibitory concentration: 4200 nM
Beside the measured number, compound 3's estimate is 1.9-fold (0.28 log units) above it; the range from low to high includes it.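

In this assay, the swap at this position gives a 1.0-fold lower number from compound 2 to compound 3 (0.01 log units; within the scatter). On the double-bonded chain carbon bound to a double-bonded ring carbon, 4-bromophenyl and 3,4-dihydroxyphenyl therefore cannot be told apart, although only the latter carries hydrogen-bond donors and acceptors. Nothing measured here accounts for this result. From the compounds shown here alone, it remains open whether a phenyl bearing an amine or a carboxylic acid would stay level with compound 3 at this place. Going by these compounds, it is also open whether any group here can give a step beyond the scatter.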